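A few compounds are considered here, and "the series" means these few. Any claim that something is new, unique, unknown or untested is made for them only; others in the source may bear on it.

Going by the values given here, compound 3 `NCc1ccc(C(=O)Nc2cccc(NC(=O)COc3ccc4c(=O)ccoc4c3)c2)cc1` gives 66 nM in an assay on isolated protein for inhibition of Rho-associated protein kinase 2 (Homo sapiens), read by scintillation counting, radiometric assay and 33P incorporation, with a stated time of 40 min, in the presence of a further agent that is not named here (on this read-out higher numbers stand for weaker inhibition and lower numbers for stronger inhibition), the highest of the three numbers so far. Compound 1 `O=C(COc1ccc2c(=O)ccoc2c1)Nc1cccc(NC(=O)c2ccccc2)c1` gives 16 nM and compound 2 `O=C(COc1ccc2c(=O)ccoc2c1)Nc1cccc(NC(=O)c2ccc([N+](=O)[O-])cc2)c1` gives 15 nM; a 4.1-fold higher number from compound 1 to compound 3 (0.62 log units; beyond the scatter) and a 4.4-fold higher number from compound 2 to compound 3 (0.64 log units; beyond the scatter), whereas a 1.1-fold lower number from compound 1 to compound 2 (0.03 log units; within the scatter). Compound 4 `Nc1ccc(C(=O)Nc2cccc(NC(=O)COc3ccc4c(=O)ccoc4c3)c2)cc1` differs from compound 3 by amino in place of aminomethyl on an aromatic carbon. Among the compounds with values here, the two steps that bear on this position are those reaching compound 3 from compound 1 and from compound 2, both modest; no measured step shortens the group while keeping its nitrogen, and the numbers for compound 1 and compound 2 show the position accepting groups of quite different kind. A small step is therefore expected in this assay, a 1.9-fold lower number from compound 3 to compound 4 (0.28 log units; within the scatter). Compound 4 is estimated at 35 nM, between 12 nM and 100 nM.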

Compound 4, half-maximal inhibitory concentration: 83 nM
Compound 4: the middle estimate sits 2.4-fold (0.38 log units) below what was measured, within the range that was stated.
By their numbers in this assay, from the lowest: compounds 2 and 1 (each within the scatter of the next); then compounds 3 and 4 (each within the scatter of the next).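

In this assay, amino and aminomethyl at this position read alike (a 1.3-fold higher number from compound 3 to compound 4 (0.10 log units; within the scatter)), so removing the carbon from 4-(aminomethyl)phenyl to give 4-aminophenyl leaves the number within the scatter. Amino also stands apart from hydrogen (a 5.2-fold higher number from compound 1 to compound 4 (0.71 log units; beyond the scatter)) and from nitro (a 5.5-fold higher number from compound 2 to compound 4 (0.74 log units; beyond the scatter)), so among these four compounds, both groups carrying an amine nitrogen give the higher numbers. The data shown offer no explanation for this. As far as these compounds go, it remains open whether a longer chain such as aminoethyl, or a carboxylic acid, would read with compounds 3 and 4 or with compounds 1 and 2.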